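The source may report more compounds than this note shows. Statements on the series, on what has been measured and on what is new or still open speak of the compounds shown alone.

Working notes on the series, read in a functional assay on MGC-803 cells (Homo sapiens) for antiproliferative activity, read by CellTiter-Glo, with a stated time of 72 h; a higher number here means a weaker inhibitor, a lower number a stronger inhibitor. Compound 1 `Cc1ccc(-c2cncc(/C=C/c3ccc(C(=O)NO)cc3)c2)cc1` gives > 10000 nM, which is a limit of the assay and not a number. Compound 2 `Cc1ccc(-c2cncc(/C=C/c3ccc(C(=O)NO)cc3)c2)c(F)c1` gives 2240 nM. Compound 3 `O=C(NO)c1ccc(/C=C/c2cncc(-c3ccccc3O)c2)cc1` gives 5460 nM, the higher of the two actual numbers, and the gap between them is a 2.4-fold higher number from compound 2 to compound 3 (0.39 log units; beyond the scatter).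

Compound 4 `COc1ccc(F)cc1-c1cncc(/C=C/c2ccc(C(=O)NO)cc2)c1` carries 5-fluoro-2-methoxyphenyl in place of 2-hydroxyphenyl on an aromatic carbon. Among the compounds with values here, the nearest precedent for the added fluoro is an at least 4.4-fold lower number from compound 1 to compound 2 (0.64 log units; beyond the scatter), although that step took place on a different aryl group. The other step into compound 3, an at least 1.8-fold lower number from compound 1 to compound 3 (0.26 log units; that floor lies within the scatter), has a floor within the scatter and adds little. Within the data shown here, no measured pair exchanges hydroxy for methoxy, so that half of the change has no precedent here. A small step towards a lower number is therefore expected, not clearly beyond the scatter. The estimated step is a 1.8-fold lower number from compound 3 to compound 4 (0.26 log units; within the scatter). Compound 4 is estimated at 3000 nM, with an expected range of 1000 nM to 9000 nM.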

Compound 4, half-maximal inhibitory concentration: 3360 nM
Beside the measured number, compound 4's estimate is 1.1-fold (0.05 log units) below it, within the range that was stated.
By their numbers in this assay, from the lowest: compounds 2, 4 and 3 (each within the scatter of the next, the first and the last beyond it). At a limit, above all of these: compound 1.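

In this assay the step of a 1.6-fold lower number from compound 3 to compound 4 (0.21 log units; within the scatter) shows that 5-fluoro-2-methoxyphenyl, with no hydrogen-bond donor, is tolerated on this aromatic carbon as well as 2-hydroxyphenyl, which carries one. The step of a 1.5-fold higher number from compound 2 to compound 4 (0.18 log units; within the scatter) likewise leaves 5-fluoro-2-methoxyphenyl and 2-fluoro-4-methylphenyl unseparated, so two differently substituted fluorophenyl groups read alike here. The remaining step of an at least 2.9-fold lower number from compound 1 to compound 4 (0.47 log units; beyond the scatter) is a floor only, since its starting value is a limit and not a number: the limit of > 10000 nM in this assay, at which 1 of the 4 values shown sits.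

The exchange of hydroxy for methoxy and the added fluoro arrive together in compound 4, so their separate shares cannot be read. On these data alone, whether an amine or a carboxylic acid on this aryl group, or a longer alkoxy chain in place of methoxy, would move the number beyond the scatter stays open.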